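The source may report more compounds than this note shows. Statements on the series, on what has been measured and on what is new or still open speak of the compounds shown alone.

Working notes on the series. Compound 1 `Cc1cn([C@H]2C[Se][C@@H](CO)O2)c(=O)[nH]c1=O` is measured in a functional assay on Vero cells (Chlorocebus sabaeus) for cytotoxicity; on this read-out lower numbers stand for stronger inhibition and higher numbers for weaker inhibition; compound 1 gives > 100000 nM, which is a limit of the assay and not a number. Compound 2 `OC[C@H]1O[C@@H](n2cnc3c(O)ncnc32)C[Se]1` reaches only a limit as well, > 100000 nM. Compound 3 `Nc1nc(O)c2ncn([C@H]3C[Se][C@@H](CO)O3)c2n1` stops at a limit too, > 100000 nM. The step that the two limits leave unreadable from compound 2 to compound 3 is therefore unreadable, and the three values share (the limit of > 100000 nM in this assay, at which 3 of the 3 values shown sit). Compound 4 `Nc1nc(O)c2ncn([C@@H]3C[Se][C@@H](CO)O3)c2n1` differs from compound 3 only as follows: the two compounds have the same atoms and bonds and differ only in configuration as drawn: 1 of 2 stereo elements differ; a stereocentre at a saturated ring carbon is drawn R in compound 3 and S in compound 4. Among the compounds with values here, no measured step concerns a change of configuration, and the single measured step cannot be read, so no direction or size can be taken from it. Compound 4 is expected to stay at the limit, estimated as 100000 nM with a range of 50000 nM to 300000 nM. The expected step of a number no higher from compound 3 to compound 4 (the limit leaves the size open) is thus none beyond the scatter.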

Compound 4, half-maximal inhibitory concentration: > 100000 nM
Compound 4 ended at the assay's limit (the forecaster's own chance of this, stated with the estimate: 85%); the middle value lies on the limit itself.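

Within the data shown here, compound 3 and compound 4 both stop at a limit of the assay, so no new step between them can be read: the limit of > 100000 nM in this assay, at which 4 of the 4 values shown sit. The compounds shown leave open whether the configuration at the saturated ring carbon, or any other change among them, shifts the value in this assay.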